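This account rests on a few compounds, and the source may have more. Where it says the series, first, only, none or still open, it means among the compounds named here.

Compound 1 `Cc1ncn2c(O)nncc12` gives > 48000 nM in a functional assay for inhibition, with Homo sapiens as the target; a higher number here means a weaker inhibitor, a lower number a stronger inhibitor.
Compound 2 `Cc1ncn2c(N(C)C)nncc12` gives > 48000 nM in this assay.
Compound 3 `Oc1nncc2cncn12` gives > 48000 nM in this assay.

Compound 1 stands only at a limit of the assay, not at a number; the same holds for compound 2 and for compound 3, since (the limit of > 48000 nM in this assay, at which 3 of the 3 values shown sit). Compound 4 `Cc1nc(CC(C)(C)C)n2c(O)nncc12` differs from compound 1 by neopentyl in place of hydrogen on an aromatic carbon. Two measured steps start from compound 1: a step that the two limits leave unreadable from compound 1 to compound 2 and a step that the two limits leave unreadable from compound 1 to compound 3. Neither step can be read in size, so there is no measured change to lean on, and neither of them touches the place where the neopentyl group enters. With every measured value sitting at the limit, the expectation for compound 4 can only be that it stays near that limit, so the step from compound 1 to compound 4 is estimated as an at least 1.2-fold lower number from compound 1 to compound 4 (0.07 log units; that floor lies within the scatter), with no direction that the data support. Compound 4 is therefore expected to give about 40000 nM in this assay, within a wide range from 5000 nM to 200000 nM.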

Compound 4, half-maximal inhibitory concentration: > 48000 nM
Compound 4: no number, only a limit; the forecaster's own chance of this, stated with the estimate: 70%; at least 1.2-fold (0.07 log units) between middle value and limit.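

In this assay compound 4 gives > 48000 nM as a limit, not a number. Among the compounds shown here, the step from compound 1 to compound 4 therefore cannot be read, and no compound here has a readable value: the limit of > 48000 nM in this assay, at which 4 of the 4 values shown sit. The compounds shown leave open whether any change to the shared core brings a measurable inhibition.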